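This account rests on a few compounds, and the source may have more. Where it says the series, first, only, none or still open, it means among the compounds named here.

Compound 1 `CCOc1cc(NC(=O)C2(NC(=O)c3ccc4c(C5CCCC5)c(-c5ncc(Cl)cn5)n(C)c4c3)CCC2)ccc1/C=C/C(=O)OCOP(=O)(O)OC(C)(C)C` is the reference point of this comparison. In an ADME assay (liver) for pharmacokinetics, with Liver microsome (Homo sapiens) as the target, using microsomes (on this read-out lower numbers stand for a shorter-lived compound and higher numbers for a longer-lived compound), compound 1 gives 1.48 h, the lowest of the two plain numbers in this set. Compound 2 `CCOc1cc(NC(=O)C2(NC(=O)c3ccc4c(C5CCCC5)c(-c5ncc(Cl)cn5)n(C)c4c3)CCC2)ccc1/C=C/C(=O)OCC(Cl)(Cl)Cl` gives > 5 h in this assay, which is a limit of the assay and not a number (the limit of > 5 h in this assay, at which 1 of the 3 values shown sits). Compound 3 `CCOc1cc(NC(=O)C2(NC(=O)c3ccc4c(C5CCCC5)c(-c5ncc(Cl)cn5)n(C)c4c3)CCC2)ccc1/C=C/C(=O)OCC(=O)OCc1ccc(Cl)cc1` gives 5.62 h in this assay. The step of an at least 3.3-fold higher number from compound 1 to compound 2 (0.52 log units; beyond the scatter) and the step of a 3.8-fold higher number from compound 1 to compound 3 (0.58 log units; beyond the scatter) both run upward, whereas the step that the limit leaves unreadable from compound 2 to compound 3 cannot be read.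

Compound 4 `CCCN(C)C(=O)COC(=O)/C=C/c1ccc(NC(=O)C2(NC(=O)c3ccc4c(C5CCCC5)c(-c5ncc(Cl)cn5)n(C)c4c3)CCC2)cc1OCC` is not yet measured in this assay. It differs from compound 1 at the same site as compounds 2 and 3 do: a group of 7 heavy atoms (5 carbon, 1 nitrogen, 1 oxygen; no ring) in place of a group of 9 heavy atoms (4 carbon, 4 oxygen, 1 phosphorus; no ring), on a saturated chain carbon bound to an oxygen next to a carbonyl group. Since both measured replacements at that site gave higher numbers, compound 4 is expected to show a 2.4-fold higher number from compound 1 to compound 4 (0.37 log units; beyond the scatter) in this assay. Compound 4 is therefore estimated at 3.5 h in this assay, within a range from 1.5 h to 8 h.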

Compound 4, half-life: 0.317 h
Estimate against measurement, compound 4: 11-fold (1.04 log units) above, outside the stated range (below it).
By their numbers in this assay, from the lowest: compound 4; then compound 1; then compound 3.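

At this position, replacing the group of compound 1 does not always raise the number: in this assay, methyl(propyl)carbamoyl gives a 4.7-fold lower number from compound 1 to compound 4 (0.67 log units; beyond the scatter), while both earlier replacements ran upward. The group's identity at this site therefore sets both the direction and the size of the step, as methyl(propyl)amino in place of (4-chlorobenzyl)oxy gives an 18-fold lower number from compound 3 to compound 4 (1.25 log units; beyond the scatter), and methyl(propyl)carbamoyl in place of trichloromethyl gives an at least 15-fold lower number from compound 2 to compound 4 (1.19 log units; beyond the scatter). The value of compound 2 is a limit of the assay and not a number, so its step is only a bound, and this is the only evidence at hand, which gives no cause for the drop: the limit of > 5 h in this assay, at which 1 of the 4 values shown sits.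

Methyl(propyl)carbamoyl is the only nitrogen-bearing group shown at this site, so it remains open whether the low number goes with the carbonyl or with the methyl and propyl on its nitrogen. As far as these compounds go, how dimethylamino, morpholine or a carboxylic acid would read here also stays open.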